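A Phenyl for a Butyl on the Shared Core

The source may hold more compounds than are shown below. What is called first, only, known or untested is meant among the compounds shown, and "the series" means these compounds.

In a functional assay on A375M cells (Homo sapiens) for cytotoxicity, read by MTT assay, with a stated time of 4 days (a higher number here means a weaker inhibitor, a lower number a stronger inhibitor), compound 1 (`C=C1CC(CCCCCCCCCCCCC)OC1=O`) gives 3900 nM and compound 2 (`C=C1CC(c2ccccc2)OC1=O`) gives 6700 nM while compound 3 (`C=C1C(=O)OC(c2ccccc2)C1CCCC`) gives 7800 nM on the same read-out. These three numbers all lie within the usual scatter of one another, so compound 3 cannot be ranked against either of the others.

Compound 4 (`C=C1C(=O)OC(c2ccccc2)C1c1ccccc1`) has not yet been measured. The structural change is phenyl in place of butyl on a saturated ring carbon and it puts phenyl in place of butyl on a saturated ring carbon. Going by the values given here, one measured step bears on this place, butyl in place of hydrogen, which gave a 1.2-fold higher number from compound 2 to compound 3 (0.07 log units; within the scatter) and stayed within the scatter. No ring at this place has been measured, so that step is only a weak guide. No step beyond the scatter is therefore expected in this assay for this exchange. The estimated step is a 1.1-fold lower number from compound 3 to compound 4 (0.05 log units; within the scatter) and it is expected to stay within the scatter. The estimate for compound 4 is 7000 nM (expected range 3000 nM to 16000 nM).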

Compound 4, half-maximal inhibitory concentration: 6300 nM
Beside the measured number, compound 4's estimate is 1.1-fold (0.05 log units) above it, and the stated range covers the measured number.
By their numbers in this assay, from the lowest: compounds 1, 4, 2 and 3 (each within the scatter of the next).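

In this assay, phenyl on this saturated ring carbon brings the first ring to this place, and it gives a 1.2-fold lower number from compound 3 to compound 4 (0.09 log units; within the scatter) in exchange for butyl and a 1.1-fold lower number from compound 2 to compound 4 (0.03 log units; within the scatter) in exchange for hydrogen. Hydrogen, butyl and phenyl at this place therefore all stand within the scatter of one another on the shared core, so neither a chain nor an aromatic ring here separates from the unsubstituted compound 2 in this assay. No supporting data on this result are available to account for it.

Going by these compounds, it remains open whether an amine, a carboxylic acid or a longer chain at this place would also stay within the scatter. On these data alone, these three compounds also all carry phenyl on the neighbouring ring atom, so it is open whether the same holds with the long chain of compound 1 there.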